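Substituting the ring amide hydrogen of compound 1

The compounds below may be only part of what the source reports. "The series", "measured", "known", "first", "only" and "open" are said of these compounds alone.

Measured compounds:
compound 1 `COc1ccc(-c2nc3cc(/C=C4\SC(=O)NC4=O)ccc3[nH]2)cc1OC` — 21700 nM
compound 2 `COc1cc(OC)c(-c2nc3cc(/C=C4\SC(=O)NC4=O)ccc3[nH]2)cc1OC` — 15300 nM

In an ADME assay on HEK-293T cells (Homo sapiens) for inhibition, read by MTT assay, with a stated time of 48 h (on this read-out lower numbers stand for stronger inhibition and higher numbers for weaker inhibition), compound 1 gives 21700 nM, the highest of the two numbers, and compound 2 gives 15300 nM. For the measured compounds named here, the single measured step, a 1.4-fold lower number from compound 1 to compound 2 (0.15 log units; within the scatter), lies within the scatter, so the two compounds cannot be ordered on this read-out.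

Compound 3 `COc1ccc(-c2nc3cc(/C=C4\SC(=O)N(CC(=O)N5CCOCC5)C4=O)ccc3[nH]2)cc1OC` differs from compound 1 by ((morpholin-4-yl)carbonyl)methyl in place of hydrogen on an amide-type nitrogen in a ring. Going by the values given here, the measured step concerns a methoxy on an aromatic carbon and leaves the ring amide nitrogen untouched, so no measured step bears on the change from compound 1 to compound 3. The estimate for compound 3 therefore rests on the number of compound 1 alone, with no grounds to expect a move beyond the scatter in either direction, and a wide range. For compound 3 the expected step is a 1.2-fold lower number from compound 1 to compound 3 (0.08 log units; within the scatter). Compound 3 is estimated at 18000 nM, between 5000 nM and 65000 nM.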

Compound 3, half-maximal inhibitory concentration: > 50000 nM
Compound 3: no number, only a limit; the forecaster's own chance of this, stated with the estimate: 15%; middle value at least 2.7-fold (0.44 log units) from the limit.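

In this assay, ((morpholin-4-yl)carbonyl)methyl in place of hydrogen on the amide-type nitrogen in the ring gives an at least 2.3-fold higher number from compound 1 to compound 3 (0.36 log units; beyond the scatter), the only step among these compounds that lies beyond the scatter. This shows that the ring amide nitrogen is a position where a change can move the read-out, here towards weaker inhibition, which the methoxy step could not show. For compound 3 the value > 50000 nM is a limit and not a number, so the full size of the step cannot be read, because the read-out ends there: the limit of > 50000 nM in this assay, at which 1 of the 3 values shown sits.

The compounds shown leave open whether this shift belongs to the morpholine-bearing group itself or to any replacement of the amide hydrogen, such as a plain methyl, a carboxylic acid or an amine on a short chain. They also leave open whether the same substitution would act alike on compound 2.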